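The compounds below may be only part of what the source reports. "The series", "measured", "known", "first", "only" and "open" are said of these compounds alone.

Working notes on the series. Within the data shown here, compound 1 `COc1cc(-c2nn(-c3cccc(NC(=O)Nc4ccc(Cl)c(Cl)c4)c3)cc2-c2ccncc2)ccc1Cl` is one of three compounds measured in a functional assay on SF-539 cells (Homo sapiens) for inhibition, read by sulforhodamine B assay, with a stated time of 48 h (on this read-out lower numbers stand for stronger inhibition of growth and higher numbers for weaker inhibition of growth), where compound 1 gives 965 nM. Compound 2 `O=C(Nc1cccc(-n2cc(-c3ccncc3)c(-c3ccc(Cl)c(O)c3)n2)c1)Nc1ccc(Cl)c(Cl)c1` gives 1340 nM and compound 3 `O=C(Nc1cccc(-n2cc(-c3ccncc3)c(-c3ccc(Cl)c(O)c3)n2)c1)Nc1cc(C(F)(F)F)cc(C(F)(F)F)c1` gives 765 nM; all three values lie within the scatter of one another, and compound 1 sits second highest of the three. Among the measured compounds shown here, the only single-point step measured, a 1.4-fold higher number from compound 1 to compound 2 (0.14 log units; within the scatter), concerns the oxygen substituent and not the urea-bearing ring.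

Compound 4 `COc1cc(-c2nn(-c3cccc(NC(=O)Nc4ccc(Cl)c(C(F)(F)F)c4)c3)cc2-c2ccncc2)ccc1Cl` differs from compound 1 by trifluoromethyl in place of chloro on an aromatic carbon. For the measured compounds named here, no measured step covers this exchange. Compounds 2 and 3 carry different groups on the same urea aryl ring and their values in this assay lie within the scatter of each other, which is the only bearing the data have on a change at that ring. A step of no more than the scatter is therefore expected in this assay from compound 1 to compound 4, namely a 1.1-fold lower number from compound 1 to compound 4 (0.06 log units; within the scatter). Compound 4 is estimated at 850 nM, with a range from 400 nM to 1800 nM.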

Compound 4, concentration for 50% growth inhibition: 1650 nM
Compound 4: middle estimate off by 1.9-fold (0.29 log units), on the low side; low and high end bracket the measured number.
By their numbers in this assay, from the lowest: compounds 3, 1, 2 and 4 (each within the scatter of the next, the first and the last beyond it).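

In this assay, among these compounds, replacing 3,4-dichlorophenyl with 4-chloro-3-(trifluoromethyl)phenyl gives a 1.7-fold higher number from compound 1 to compound 4 (0.23 log units; within the scatter) and is the first single-place step on this ring of the urea. At this position, trifluoromethyl and chloro cannot be told apart in this read-out, so the step adds a second change within the scatter to the one at the oxygen substituent, a 1.4-fold higher number from compound 1 to compound 2 (0.14 log units; within the scatter). No measurement offered here accounts for the small step seen with this exchange.

As far as these compounds go, whether an amine, a nitrile or a carboxylic acid in place of chloro at this position would also stay within the scatter of compound 1 remains open. Also open, from the compounds shown here alone, is whether the same chloro to trifluoromethyl exchange would give a similar step on compound 2, which carries hydroxy in place of methoxy.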